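A Propyl Chain Replaces the Dihydroxypropylcarbamoyl Arm

A few compounds are considered here, and "the series" means these few. Any claim that something is new, unique, unknown or untested is made for them only; others in the source may bear on it.

Compound 3 `Cn1ncc(Cl)c1-c1cc(C(=O)N[C@@H]2CN[C@H](CC(=O)NCC(O)CO)C[C@H]2c2ccc(Cl)c(Cl)c2)oc1Cl` gives 3.13 nM in an assay for inhibition of RAC-alpha serine/threonine-protein kinase (Homo sapiens), read by HTRF, with a stated time of 1 h (a higher number here means a weaker inhibitor, a lower number a stronger inhibitor), and sits second highest of the three numbers, between compound 2 `Cn1ncc(Cl)c1-c1cc(C(=O)N[C@@H]2CN[C@H](CC(=O)O)C[C@H]2c2ccc(Cl)c(Cl)c2)oc1Cl` with 1.94 nM and compound 1 `Cn1ncc(Cl)c1-c1cc(C(=O)N[C@@H]2CN[C@H](CCN3CCCCC3)C[C@H]2c2ccc(Cl)c(Cl)c2)oc1Cl` with 5.65 nM. Compound 4 `CCC[C@@H]1C[C@@H](c2ccc(Cl)c(Cl)c2)[C@H](NC(=O)c2cc(-c3c(Cl)cnn3C)c(Cl)o2)CN1` carries the change (ethyl in place of (2,3-dihydroxypropyl)carbamoyl on a saturated chain carbon bound to a saturated ring carbon). Earlier steps at this place were small: a 2.9-fold lower number from compound 1 to compound 2 (0.46 log units; beyond the scatter), a 1.8-fold lower number from compound 1 to compound 3 (0.26 log units; within the scatter) and a 1.6-fold higher number from compound 2 to compound 3 (0.21 log units; within the scatter). Since each of these side-chain swaps left this assay nearly unmoved, the expectation for compound 4 is a step of a 1.3-fold higher number from compound 3 to compound 4 (0.11 log units; within the scatter), that is, none clearly beyond the scatter. Compound 4 is therefore estimated at 4 nM, within a range of 1.5 nM to 12 nM, in this assay.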

Compound 4, half-maximal inhibitory concentration: 10.4 nM
Compound 4: the middle estimate sits 2.6-fold (0.41 log units) below what was measured, and the stated range covers the measured number.
By their numbers in this assay, from the lowest: compounds 2, 3, 1 and 4 (each within the scatter of the next, the first and the last beyond it).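

At this place, on a saturated chain carbon bound to a saturated ring carbon, swapping the polar-free... 

Correction, final text:

At this place, on a saturated chain carbon bound to a saturated ring carbon, ethyl weakens inhibition in this assay relative to both the (2,3-dihydroxypropyl)carbamoyl arm (a 3.3-fold higher number from compound 3 to compound 4 (0.52 log units; beyond the scatter)) and the carboxy arm (a 5.4-fold higher number from compound 2 to compound 4 (0.73 log units; beyond the scatter)). The plain propyl chain cannot be told apart from the piperidine-bearing chain (a 1.8-fold higher number from compound 1 to compound 4 (0.26 log units; within the scatter)), so the arms do not all sit level. Nothing measured here accounts for these differences. The compounds shown leave open how a primary amine or a longer alkyl chain would read at this place, and whether a simple hydroxyethyl chain would match the carbamoyl arm.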